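Adding an Amino Group to Compound 3

The source may hold more compounds than are shown below. What is called first, only, known or untested is meant among the compounds shown, and "the series" means these compounds.

In an ADME assay on HeLa cells (Homo sapiens) for cytotoxicity, read by crystal violet staining, with a stated time of 72 h (a lower number here means that less compound is tolerated, a higher number that more compound is tolerated), compound 3 (`CN(C)C(=O)c1cc(CCCOc2ccc(-c3noc(C(F)(F)F)n3)cc2)on1`) gives 28000 nM. Compound 1 (`COC(=O)c1cc(CCCOc2c(C)cc(-c3noc(C(F)(F)F)n3)cc2C)on1`) gives 35400 nM, which lies within the scatter of the value for compound 3. Compound 2 (`CCOC(=O)c1cc(CCCOc2ccc(-c3noc(C(F)(F)F)n3)cc2)on1`) gives > 100000 nM, which is a limit of this assay and not a number.

Compound 4 (`CN(C)C(=O)c1cc(CCCOc2ccc(-c3noc(C(F)(F)F)n3)cc2N)on1`) has amino in place of hydrogen on an aromatic carbon. For the measured compounds named here, the only measured step that touches compound 3 is an at least 3.5-fold lower number from compound 2 to compound 3 (0.55 log units; beyond the scatter). That step has dimethylamino in place of ethoxy on a carbonyl carbon, so it is a different change at a different place, and its size rests on a limit. Going by the values given here, no measured step shows what amino does on an aromatic carbon, so neither its size nor its direction can be carried over. The expectation is therefore a 1.1-fold lower number from compound 3 to compound 4 (0.05 log units; within the scatter), with no change beyond the scatter. Compound 4 is estimated at 25000 nM, with an expected range from 9000 nM to 70000 nM.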

Compound 4, half-maximal cytotoxic concentration: 90800 nM
Beside the measured number, compound 4's estimate is 3.6-fold (0.56 log units) below it, and the stated range ends below it.
By their numbers in this assay, from the lowest: compounds 3 and 1 (each within the scatter of the next); then compound 4. At a limit, above all of these: compound 2.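

In this assay, placing amino on the aromatic carbon ortho to a large group and meta to the 5-(trifluoromethyl)-1,2,4-oxadiazol-3-yl group gives a 3.2-fold higher number from compound 3 to compound 4 (0.51 log units; beyond the scatter), so this single added heavy atom on the six-membered aromatic ring is enough to shift the number beyond the scatter. For the compounds shown here, the only earlier step, at the carbonyl carbon, ran the other way, with an at least 3.5-fold lower number from compound 2 to compound 3 (0.55 log units; beyond the scatter). That step starts from compound 2, whose value is a limit of the assay and not a number: the limit of > 100000 nM in this assay, at which 1 of the 4 values shown sits.

On these data alone, whether a hydroxyl group, a fluorine atom or an acetylated amine at this same position would shift the number in the same way stays open. Also open, as far as these compounds go, is whether amino does the same in the ester compounds, since this one step comes from a single dimethylamide pair.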